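The source may hold more compounds than are shown below. What is called first, only, known or untested is meant among the compounds shown, and "the series" means these compounds.

Measured so far:
- compound 1 `CC[C@@H](Nc1c(Nc2cccc(C(N)=O)c2O)c(=O)c1=O)c1ccccc1`: 804 ng.h/mL
- compound 2 `CC[C@@H](Nc1c(Nc2c(C)ccc(C(=O)N(C)C)c2O)c(=O)c1=O)c1ccccc1`: 937 ng.h/mL

In an ADME assay on the whole organism (plasma) for pharmacokinetics, with Rattus norvegicus as the target, at a dose of 10 mg/kg by the oral route (on this read-out lower numbers stand for lower exposure and higher numbers for higher exposure at the dose given), compound 1 gives 804 ng.h/mL. This stands within the usual scatter of compound 2 at 937 ng.h/mL, so the two measured compounds cannot be separated on this read-out.

The next compound to be read is compound 3 `CC[C@@H](Nc1c(Nc2cccc(C(=O)N(C)C(C)C)c2O)c(=O)c1=O)c1ccccc1`. It differs from compound 1 in one place, with isopropyl(methyl)amino in place of amino on a carbonyl carbon. The same difference can be read as carbamoyl to isopropyl(methyl)carbamoyl.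

Going by the values given here, no measured pair differs in one place, so the size of this change in this assay cannot be gauged directly. Among the compounds with values here, the only guide is that compound 1 at 804 ng.h/mL and compound 2 at 937 ng.h/mL lie within the scatter of each other. From the compounds shown here alone, on that thin basis, no step beyond the scatter is expected, and the direction remains open. The expected step is a 1.1-fold higher number from compound 1 to compound 3 (0.05 log units; within the scatter). For compound 3 the estimated value is 900 ng.h/mL, with an expected range of 250 ng.h/mL to 3000 ng.h/mL.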

Compound 3, area under the concentration-time curve: 590 ng.h/mL
For compound 3 the middle estimate is 1.5-fold (0.18 log units) above the measured one; measured number inside the range.
By their numbers in this assay, from the lowest: compounds 3, 1 and 2 (each within the scatter of the next).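

In this assay, going by these compounds alone, the pair of compound 1 and compound 3 is the first measured pair that differs in one place, and it gives a 1.4-fold lower number from compound 1 to compound 3 (0.13 log units; within the scatter) within the usual scatter. Within the data shown here, on this carbonyl carbon, isopropyl(methyl)amino with 5 heavy atoms and 0 hydrogen-bond donors therefore stands in place of amino with 1 heavy atom and 1 hydrogen-bond donor, with no step that this read-out can separate from repeat measurement. No measured property bears on this result, so nothing can be said about what lies behind it.

This single pair leaves open whether the position tolerates other replacements in the same way, such as a ring amine like morpholine or pyrrolidine on the carbonyl carbon, or a carboxylic acid in place of the carbamoyl group. It also leaves open whether the absence of a step beyond the scatter would hold on a different core, since the exposure figure alone gives no view of the separate processes that feed into it.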